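The source may report more compounds than this note shows. Statements on the series, on what has been measured and on what is new or still open speak of the compounds shown alone.

Compound 3 `CC(=O)c1ccc(NC(=S)Nc2ccc3[nH]ccc3c2)cc1` is the only one of the three measured compounds with a number in an ADME assay on cells for inhibition of Amine oxidase [flavin-containing] A (Homo sapiens), read by spectrophotometry; a lower number here means a stronger inhibitor, a higher number a weaker inhibitor: in that assay compound 3 gives 67000 nM. Compound 1 `Oc1ccc(NC(=S)Nc2ccc3[nH]ccc3c2)cc1` is reported in this assay without a number, compound 1 giving "not active" (no number reported). Compound 2 `OCc1ccc(NC(=S)Nc2ccc3[nH]ccc3c2)cc1` is reported the same way, compound 2 giving "not active" (no number reported). Compound 4 `CC(=O)Nc1ccc(NC(=S)Nc2ccc3[nH]ccc3c2)cc1` has not yet been measured; it differs from compound 3 by acetamido in place of acetyl on an aromatic carbon. Going by the values given here, no step between two measured compounds is available for comparison, and compound 1 and compound 2 offer no numbers to lean on. Compound 4 is expected to lose some potency, by a 1.6-fold higher number from compound 3 to compound 4 (0.22 log units; within the scatter), a step that may go beyond the scatter. Compound 4 is therefore estimated at 110000 nM, within 40000 nM to 300000 nM, with a real chance that only inactivity is reported.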

Compound 4, half-maximal inhibitory concentration: 71000 nM
For compound 4 the middle estimate is 1.5-fold (0.19 log units) above the measured one; the range from low to high includes it.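

In this assay putting acetamido in place of acetyl on the aromatic carbon para to a large group gives a 1.1-fold higher number from compound 3 to compound 4 (0.03 log units; within the scatter) and so leaves the reading within the scatter, even with one more heavy atom and a hydrogen-bond donor in the group. Going by these compounds alone, this is the first step at this position that can be read as a number. Nothing measured here accounts for this result. The compounds shown leave open whether an amine or a carboxylic acid at this position would give a number at all. They also leave open whether a longer chain on the acetamido would keep the reading where it stands.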